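Notes on a second chloro group in the series

This account rests on a few compounds, and the source may have more. Where it says the series, first, only, none or still open, it means among the compounds named here.

Values in a physicochemical assay for solubility, at pH 7.4; a lower number here means a less soluble compound, a higher number a more soluble compound:
- compound 1 `O=C(N[C@H]1CN(S(=O)(=O)c2ccccc2)C[C@@H]1C(=O)N[C@H]1CCCNC1)c1cc(-c2ccccc2)on1`: 94000 nM
- compound 2 `O=C(N[C@H]1CN(S(=O)(=O)c2ccccc2)C[C@@H]1C(=O)N[C@H]1CCCNC1)c1cc(-c2ccc(Cl)cc2)on1`: 12000 nM
- compound 3 `O=C(N[C@H]1CN(S(=O)(=O)c2ccccc2)C[C@@H]1C(=O)N[C@H]1CCCNC1)c1cc(-c2ccccc2Cl)on1`: 12000 nM

Compound 3 stands level with compound 2, together the lowest of the three numbers. The next structure, compound 4 `O=C(N[C@H]1CN(S(=O)(=O)c2ccccc2)C[C@@H]1C(=O)N[C@H]1CCCNC1)c1cc(-c2ccc(Cl)cc2Cl)on1`, goes from 2-chlorophenyl to 2,4-dichlorophenyl: chloro in place of hydrogen on an aromatic carbon. It is chloro in place of hydrogen on an aromatic carbon, meta to a chloro group and para to a large group.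

Two measured steps make this kind of change: a 7.8-fold lower number from compound 1 to compound 2 (0.89 log units; beyond the scatter) and a 7.8-fold lower number from compound 1 to compound 3 (0.89 log units; beyond the scatter), both modest and beyond the scatter. The step of no change at the digits printed from compound 2 to compound 3 (within the scatter) lies within the scatter. Neither chloro step starts from a compound already carrying chloro, so the size carries over only loosely. A further modest fall in this assay is expected.

The expected change is a 6.0-fold lower number from compound 3 to compound 4 (0.78 log units; beyond the scatter). For compound 4 the estimate is 2000 nM, with an expected range of 600 nM to 7000 nM.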

Compound 4, solubility: 4000 nM
Estimate against measurement, compound 4: 2.0-fold (0.30 log units) below; measured number inside the range.
By their numbers in this assay, from the lowest: compound 4; then compounds 2 and 3 (each within the scatter of the next); then compound 1.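

In this assay a second chloro group on a ring already carrying one still lowers the number, with a 3.0-fold lower number from compound 3 to compound 4 (0.48 log units; beyond the scatter) and a 3.0-fold lower number from compound 2 to compound 4 (0.48 log units; beyond the scatter) showing the same size whichever chloro group stands first. The full change to 2,4-dichlorophenyl gives a 24-fold lower number from compound 1 to compound 4 (1.37 log units; beyond the scatter) and so counts as large, where each single chloro step was modest.

From the compounds shown here alone, whether fluoro, methoxy or an amine at this place on the ring would give a step of similar size stays open. Nothing measured here explains the fall.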